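The source may report more compounds than this note shows. Statements on the series, on what has been measured and on what is new or still open speak of the compounds shown alone.

Measured compounds in a functional assay on MCF7 cells (Homo sapiens) for cytotoxicity, read by MTT assay, with a stated time of 72 h; on this read-out lower numbers stand for stronger inhibition and higher numbers for weaker inhibition:

Compound 1, `O=C(Nc1ccc(Oc2ccnc3[nH]ccc23)c(F)c1)c1nn(-c2ccc(Cl)cc2)ccc1=O`. In this assay compound 1 gives > 60000 nM, which is a limit of the assay and not a number.
Compound 2, `O=C(Nc1ccc(Oc2ccnc3[nH]ccc23)c(F)c1)c1nn(-c2ccc(Br)cc2F)ccc1=O`. Compound 2 gives 23500 nM.
Compound 3, `Cc1cc(=O)n(-c2cccc(F)c2)nc1C(=O)Nc1ccc(Oc2ncnc3[nH]ccc23)cc1`. Compound 3 gives 9670 nM.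

Compound 3 holds the lowest of the two numbers shown; the nearest is compound 2, and the gap between the two lies beyond the usual scatter, while the remaining value is a limit. Compound 4, `Cc1cc(=O)n(-c2ccccc2OC(F)(F)F)nc1C(=O)Nc1ccc(Oc2ncnc3[nH]ccc23)cc1`, has not been measured. It differs from compound 3 in one place: 2-(trifluoromethoxy)phenyl in place of 3-fluorophenyl on an aromatic nitrogen.

Among the compounds with values here, only one measured step touches the same place, the aryl group on the aromatic nitrogen: an at least 2.5-fold lower number from compound 1 to compound 2 (0.40 log units; beyond the scatter). Its size cannot be fixed more closely because of the limit of > 60000 nM in this assay, at which 1 of the 3 values shown sits. That step shows a change of the aryl substitution at this position can move the number by a modest amount. The change from compound 3 to compound 4 is a different one, so the direction is uncertain; a modest step, or none beyond the scatter, is expected. The expected step is a 1.2-fold higher number from compound 3 to compound 4 (0.09 log units; within the scatter). Compound 4 is therefore estimated at 12000 nM, within a range from 4000 nM to 36000 nM.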

Compound 4, half-maximal inhibitory concentration: 32000 nM
Beside the measured number, compound 4's estimate is 2.7-fold (0.43 log units) below it; the range from low to high includes it.
By their numbers in this assay, from the lowest: compound 3; then compounds 2 and 4 (each within the scatter of the next). At a limit, above all of these: compound 1.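

In this assay, 2-(trifluoromethoxy)phenyl in place of 3-fluorophenyl on the aromatic nitrogen gives a 3.3-fold higher number from compound 3 to compound 4 (0.52 log units; beyond the scatter), so the number at this position moves upward as well as downward, depending on the aryl group and the compounds involved. This is also the first step at this position with a measured number at both ends, whereas the only earlier step could be sized from one side alone: the limit of > 60000 nM in this assay, at which 1 of the 4 values shown sits. Nothing shown here bears on why the number rises with this change.

Compound 3 and compound 4 differ both in the substituent on the phenyl ring and in where it sits, and this single pair cannot tell those two changes apart. From the compounds shown here alone, how the number in this assay would respond to a phenyl ring carrying an amine or a carboxylic acid, or to a longer alkyl chain in place of the aryl group on this nitrogen, remains open.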